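Trimming one methoxy from the trimethoxyphenyl ketone

A few compounds are considered here, and "the series" means these few. Any claim that something is new, unique, unknown or untested is made for them only; others in the source may bear on it.

Compound 3 `COc1cc(C(=O)c2ccc3c(ccn3S(=O)(=O)c3cccc(/C=C/C(=O)NO)c3)c2)cc(OC)c1OC` gives the lowest number of the three measured, at 562 nM in an assay on isolated protein for inhibition of protein deacetylase HDAC6 (Homo sapiens); a higher number here means a weaker inhibitor, a lower number a stronger inhibitor. Compound 1 `COc1cc(C(=O)c2ccc3c(ccn3S(=O)(=O)c3ccc(/C=C/C(=O)NO)cc3)c2)cc(OC)c1OC` gives 972 nM, and compound 2 `COc1cccc(C(=O)c2ccc3c(ccn3S(=O)(=O)c3cccc(/C=C/C(=O)NO)c3)c2)c1` gives 1810 nM. Compound 4 `COc1ccc(C(=O)c2ccc3c(ccn3S(=O)(=O)c3cccc(/C=C/C(=O)NO)c3)c2)cc1OC` differs from compound 3 by hydrogen in place of methoxy on an aromatic carbon. Within the data shown here, the one measured step that bears on this is a 3.2-fold lower number from compound 2 to compound 3 (0.51 log units; beyond the scatter), in which the trimethoxyphenyl group took the place of a methoxyphenyl group. Compound 4 stands part of the way back toward compound 2. A small rise in the number is therefore expected for compound 4, near the edge of the scatter, as a 1.5-fold higher number from compound 3 to compound 4 (0.18 log units; within the scatter). Compound 4 is estimated at 850 nM, with a range from 400 nM to 1800 nM.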

Compound 4, half-maximal inhibitory concentration: 1180 nM
For compound 4 the middle estimate is 1.4-fold (0.14 log units) below the measured one; the measured number falls inside the stated range.
By their numbers in this assay, from the lowest: compounds 3, 1, 4 and 2 (each within the scatter of the next, the first and the last beyond it).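

Cutting 3,4,5-trimethoxyphenyl back to 3,4-dimethoxyphenyl gives a 2.1-fold higher number from compound 3 to compound 4 (0.32 log units; beyond the scatter), so this one methoxy, with hydrogen in its place, accounts for a step of its own. The other added methoxy, on the way from the 3-methoxyphenyl group, gives a 1.5-fold lower number from compound 2 to compound 4 (0.19 log units; within the scatter), so the gain seen from compound 2 to compound 3 is resolved only once the third methoxy is present. No supporting evidence on the reason for this is available. On these data alone, whether a hydroxy group, a fluorine atom or an ethoxy group could stand in for this methoxy remains open, as does whether its loss counts equally with the 4-(2-(hydroxycarbamoyl)ethenyl)phenyl group of compound 1.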